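The source may hold more compounds than are shown below. What is called first, only, known or untested is meant among the compounds shown, and "the series" means these compounds.

Three compounds have been measured in a functional assay on A549 cells (Homo sapiens) for inhibition, read by CCK-8 assay, with a stated time of 72 h, tested at 10 uM; on this read-out higher numbers stand for more inhibition of growth at the one concentration tested and lower numbers for less inhibition of growth:

Compound 1 `CN(C)C(=O)c1cc2cnc(Nc3ccc(NC(=O)C4(C(=O)Nc5ccc(Br)cc5)CC4)cc3)nc2n1C1CCCC1`: 90.3%
Compound 2 `Cc1cccc(NC(=O)C2(C(=O)Nc3ccc(Nc4ncc5cc(C(=O)N(C)C)n(C6CCCC6)c5n4)cc3)CC2)c1`: 86.1%
Compound 3 `CN(C)C(=O)c1cc2cnc(Nc3ccc(NC(=O)C4(C(=O)Nc5ccc(C(F)(F)F)cc5)CC4)cc3)nc2n1C1CCCC1`: 87.9%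

Compound 2 has the lowest of the three numbers, but its separation from the others is small: compound 3 is nearest, with a number 1.8 percentage points higher from compound 2 to compound 3 (within the scatter), and compound 1 furthest, with a number 4.2 percentage points lower from compound 1 to compound 2 (within the scatter). Both steps lie within the scatter, so the three compounds cannot be placed in any order on these numbers.

Compound 4 `CN(C)C(=O)c1cc2cnc(Nc3ccc(NC(=O)C4(C(=O)Nc5ccc(F)cc5)CC4)cc3)nc2n1C1CCCC1` is not yet measured. It differs from compound 2 as follows: 4-fluorophenyl in place of 3-methylphenyl on an amide-type nitrogen. Going by the values given here, two measured steps bear on this change, since both also exchange the 3-methylphenyl for a phenyl carrying a single substituent: a number 4.2 percentage points lower from compound 1 to compound 2 (within the scatter) and a number 1.8 percentage points higher from compound 2 to compound 3 (within the scatter), each within the scatter. The step of a number 2.4 percentage points lower from compound 1 to compound 3 (within the scatter) adds that exchanging one substituent on that ring for another also left the number within the scatter. Among the compounds with values here, nothing among the measured compounds suggests that a 4-fluorophenyl in this place would behave differently, so compound 4 is expected to show no step beyond the scatter, a number 1.9 percentage points higher from compound 2 to compound 4 (within the scatter). The estimate for compound 4 in this assay is 88%, with a range from 78% to 96%.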

Compound 4, percent growth inhibition at one concentration: 102%
The estimate for compound 4 lay 14 percentage points below the measured number; measured number outside the range, above it.
By their numbers in this assay, from the lowest: compounds 2, 3 and 1 (each within the scatter of the next); then compound 4.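

On the amide-type nitrogen, the 4-fluorophenyl of compound 4 sets it apart from all three earlier compounds in this assay, with a number 15.9 percentage points higher from compound 2 to compound 4 (beyond the scatter), a number 14.1 percentage points higher from compound 3 to compound 4 (beyond the scatter) and a number 11.7 percentage points higher from compound 1 to compound 4 (beyond the scatter). The earlier exchanges among 4-bromophenyl, 3-methylphenyl and 4-(trifluoromethyl)phenyl had all stayed within the scatter, so this position had seemed indifferent to the group it carried, and compound 4 shows that it is not: fluoro in place of bromo or trifluoromethyl on the same aromatic carbon is enough to move the number beyond the scatter. Nothing available here accounts for this step. From the compounds shown here alone, it remains open whether a chloro or a methoxy in place of the fluoro on that aromatic carbon, or a plain phenyl on the amide-type nitrogen, would stand with compound 4 or with compounds 1, 2 and 3. Also open, going by these compounds, is whether compound 4 would keep its place across a range of concentrations, as a read-out at one concentration cannot tell this.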